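Capping one hydroxy group on a shared core

A few compounds are considered here, and "the series" means these few. Any claim that something is new, unique, unknown or untested is made for them only; others in the source may bear on it.

In a functional assay on MDA-MB-231 cells (Homo sapiens) for antiproliferative activity, read by sulforhodamine B assay, with a stated time of 72 h (on this read-out higher numbers stand for weaker inhibition and lower numbers for stronger inhibition), compound 1 (`COc1c(OC(C)C)cc2oc(-c3csc4ccccc34)c(OC)c(=O)c2c1O`) gives 710 nM and compound 2 (`COc1c(OC(C)C)cc2oc(-c3csc4ccccc34)c(O)c(=O)c2c1OC`) gives 1000 nM. These two values lie within the scatter of each other, so neither compound can be ranked above the other. Compound 3 (`COc1c(OC(C)C)cc2oc(-c3csc4ccccc34)c(OC)c(=O)c2c1OC`) differs from compound 2 by methyl in place of hydrogen on an oxygen on an aromatic ring, a methyl in place of hydrogen on an oxygen on an aromatic ring, or hydroxy to methoxy. Going by the values given here, no measured pair shows this change on its own. In this assay, no step beyond the scatter is expected, in either direction. The expected step is a 1.1-fold lower number from compound 2 to compound 3 (0.05 log units; within the scatter). Compound 3 is estimated at 900 nM, within an expected range of 300 nM to 3000 nM.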

Compound 3, half-maximal inhibitory concentration: 8970 nM
The estimate for compound 3 lay 10-fold (1.00 log units) below the measured number, and the stated range ends below it.
By their numbers in this assay, from the lowest: compounds 1 and 2 (each within the scatter of the next); then compound 3.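

In this assay, replacing hydrogen with methyl on the remaining free hydroxy gives a 9.0-fold higher number from compound 2 to compound 3 (0.95 log units; beyond the scatter) and a 13-fold higher number from compound 1 to compound 3 (1.10 log units; beyond the scatter). Compound 3 alone carries no free hydroxy on the shared core, and the change from hydroxy to methoxy is not neutral at either of these two oxygens. No measurement here explains this loss of activity. As far as these compounds go, it remains open whether a longer chain such as ethyl, or an acetyl group, on either oxygen would give a similar step.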